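Methoxy to Chloro: Expecting Slower Clearance for Compound 4

The source may hold more compounds than are shown below. What is called first, only, known or untested is meant among the compounds shown, and "the series" means these compounds.

Of the compounds shown here, three have been measured in an ADME assay on microsomes from liver (Homo sapiens) for metabolic stability, tested at 2.5 uM; on this read-out lower numbers stand for slow clearance and higher numbers for fast clearance. Compound 1 `O=S(=O)(c1ccc(F)cc1)c1cnc2ccc(Cl)cc2c1-c1ccc(Cl)cc1` gives 0.01 mL/min, compound 3 `O=S(=O)(c1ccc(F)c(Cl)c1)c1cnc2cc(F)ccc2c1-c1ccc(Cl)cc1` gives 0.39 mL/min, and compound 2 `COc1ccc(-c2c(S(=O)(=O)c3cc(F)cc(F)c3)cnc3c(F)cccc23)cc1` gives 2.59 mL/min. Compound 2 thus stands highest of the three numbers, with compound 3 its nearest neighbour and compound 1 far below it, both gaps lying beyond the usual scatter.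

The unmeasured compound 4 `O=S(=O)(c1cc(F)cc(F)c1)c1cnc2c(F)cccc2c1-c1ccc(Cl)cc1` differs from compound 2 in one place: chloro in place of methoxy on an aromatic carbon. Both compounds already measured with 4-chlorophenyl run slowly: compound 3 gives 0.39 mL/min and compound 1 gives 0.01 mL/min in this assay . On that basis the expected step is a 5.2-fold lower number from compound 2 to compound 4 (0.71 log units; beyond the scatter), downward toward slower clearance and beyond the scatter. Compound 4 is therefore estimated at 0.5 mL/min, within a range from 0.1 mL/min to 2 mL/min.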

Compound 4, intrinsic clearance in a liver preparation (reported as CLH), per the amount of preparation that the assay uses: 0.73 mL/min
For compound 4 the middle estimate is 1.5-fold (0.16 log units) below the measured one, and the stated range covers the measured number.
By their numbers in this assay, from the lowest: compound 1; then compounds 3 and 4 (each within the scatter of the next); then compound 2.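

Among these compounds, this is the first pair that differs in one place only, so the change can be read on its own: in this assay, 4-methoxyphenyl to 4-chlorophenyl gives a 3.5-fold lower number from compound 2 to compound 4 (0.55 log units; beyond the scatter), with the rest of the molecule unchanged. The step is modest, yet it shows that this single swap is enough to move clearance toward the slower end. Nothing shown here bears on the reason for the step. As far as these compounds go, how other groups on this aromatic carbon, such as an amine or a longer chain like ethoxy, would behave stays open. So does whether the same swap gives a similar step on the core of compound 1.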